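Nitro group relocation, compound 2 to compound 3

The compounds below may be only part of what the source reports. "The series", "measured", "known", "first", "only" and "open" are said of these compounds alone.

Within the data shown here, compound 2 (`C[C@H]1CC[C@@H]2[C@@H](OC(=O)[C@]23CC(c2ccccc2[N+](=O)[O-])=NO3)[C@]2(C)C(=O)C=C[C@@]12O`) gives 1.37 in a physicochemical assay for lipophilicity (on this read-out lower numbers stand for lower lipophilicity and higher numbers for higher lipophilicity), the lower of the two numbers so far, while compound 1 (`C[C@H]1CC[C@@H]2[C@@H](OC(=O)[C@]23CC(c2ccccc2Br)=NO3)[C@]2(C)C(=O)C=C[C@@]12O`) gives 2.22. Compound 3 (`C[C@H]1CC[C@@H]2[C@@H](OC(=O)[C@]23CC(c2ccc([N+](=O)[O-])cc2)=NO3)[C@]2(C)C(=O)C=C[C@@]12O`) has the same atoms as compound 2, joined differently: 4-nitrophenyl in place of 2-nitrophenyl on a carbon with a double bond to nitrogen. Among the measured compounds shown here, the one measured step, a number 0.85 log units lower from compound 1 to compound 2 (beyond the scatter), is modest and beyond the scatter. For the measured compounds named here, it exchanges bromo for nitro on an aromatic carbon, so it bears only indirectly, and no measured step shows what a shift of the nitro group does. With the group and its counts unchanged, no step beyond the scatter is expected in this assay. The estimated step is a number 0.13 log units higher from compound 2 to compound 3 (within the scatter). For compound 3 the expected value is 1.5, with an estimated range from 1.15 to 1.85.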

Compound 3, partition coefficient: 1.37
Compound 3: the middle estimate sits 0.13 log units above what was measured, and the stated range covers the measured number.
By their numbers in this assay, from the lowest: compounds 2 and 3 (each within the scatter of the next); then compound 1.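

Relocating the nitro group, with 4-nitrophenyl in place of 2-nitrophenyl on the carbon with a double bond to nitrogen, gives in this assay no change at the digits printed from compound 2 to compound 3 (within the scatter), so this read-out does not separate the two arrangements of the same atoms at this place on the shared core. The exchange of 2-bromophenyl for 4-nitrophenyl gives a number 0.85 log units lower from compound 1 to compound 3 (beyond the scatter), the same size as a number 0.85 log units lower from compound 1 to compound 2 (beyond the scatter), so the gap to the bromo compound holds for both nitrophenyl compounds. No supporting data bear on why the two nitrophenyl compounds read alike.

Open, from the compounds shown here alone, is whether an amine or a carboxylic acid in place of the nitro group would also give the same number at both ring placements. Also open, going by these compounds, is how a methoxy group would read at this place on the core.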